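This account rests on a few compounds, and the source may have more. Where it says the series, first, only, none or still open, it means among the compounds named here.

The series shares one core, seen in compound 1 `CCc1cc(Cn2c(CC)nc3c(C)cc(C)nc32)ccc1OC(C(=O)O)c1ccccc1`, which in an assay on Midbrain with Type-2 angiotensin II receptor (Rattus norvegicus) as the target (a lower number here means a stronger inhibitor, a higher number a weaker inhibitor), gives 410 nM. Compound 2 `CCc1nc2c(C)cc(C)nc2n1Cc1ccc(OC(C(=O)O)c2ccccc2)c(Cc2ccccc2)c1` differs from it in one place, and the step of a 2.0-fold higher number from compound 1 to compound 2 (0.29 log units; within the scatter) is the only one recorded. In this assay compound 2 gives 800 nM, the highest of the two numbers shown; the nearest is compound 1, and the two lie within the scatter of each other, so no order between them can be read.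

Compound 3 `CCc1nc2c(C)cc(C)nc2n1Cc1ccc(OC(C(=O)O)c2ccccc2)c(C(=O)c2ccccc2)c1` is the next compound. It differs from compound 2 by benzoyl in place of benzyl on an aromatic carbon. Among the compounds with values here, no measured step bears on this change: the one step recorded, from compound 1 to compound 2, altered a saturated chain carbon rather than replacing a benzyl group with a benzoyl group, and it itself stayed within the scatter. Within the data shown here, with no comparable step to draw on, compound 3 is expected to stay close to compound 2, with an estimated step of no change at the digits printed from compound 2 to compound 3 (within the scatter). The estimate for compound 3 in this assay is therefore 800 nM, within a range from 300 nM to 2200 nM.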

Compound 3, half-maximal inhibitory concentration: 60 nM
The estimate for compound 3 lay 13-fold (1.12 log units) above the measured number; measured number below the stated range.
By their numbers in this assay, from the lowest: compound 3; then compounds 1 and 2 (each within the scatter of the next).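

The position ortho to a carboxy(phenyl)methoxy group turns out to respond to what is placed there: in this assay, benzoyl in place of benzyl gives a 13-fold lower number from compound 2 to compound 3 (1.12 log units; beyond the scatter). Benzoyl in place of ethyl gives a 6.8-fold lower number from compound 1 to compound 3 (0.83 log units; beyond the scatter), so compound 3 stands apart from both earlier compounds, whereas the step between those two, a 2.0-fold higher number from compound 1 to compound 2 (0.29 log units; within the scatter), gave no sign that this position mattered. Benzyl and benzoyl each bring one six-membered aromatic ring of carbon only, so the large step goes with a change in the link to that ring, which adds a carbonyl with 1 hydrogen-bond acceptor and not a new ring or a different ring type.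

Nothing measured here says what about the benzoyl group lies behind the lower number. Still open, on these data alone, is whether other links between the aromatic carbon and the phenyl ring, such as an amide, a sulfonyl or a hydroxymethylene, would give a number like that of compound 3, and whether substituents such as chlorine or methoxy on the benzoyl phenyl ring would move it further.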